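The source may hold more compounds than are shown below. What is called first, only, known or untested is meant among the compounds shown, and "the series" means these compounds.

Compound 1 `COc1cccc(CCC(=O)Nc2nc3ccccc3c(=O)s2)c1` gives 173 nM in an assay on CHO cells for displacement of a labelled ligand from adenosine receptor A3 (Homo sapiens), read by scintillation counting, with a stated time of 60 min; on this read-out lower numbers stand for stronger inhibition and higher numbers for weaker inhibition. Compound 2 `O=C(CCCc1ccccc1)Nc1nc2ccccc2c(=O)s1` carries a longer chain ending in a plain phenyl ring. In this assay compound 2 reaches only > 1000 nM, a boundary of the assay rather than a number, as recorded by the limit of > 1000 nM in this assay, at which 1 of the 2 values shown sits. Compound 3 `COc1cccc(CCCC(=O)Nc2nc3ccccc3c(=O)s2)c1` differs from compound 2 by methoxy in place of hydrogen on an aromatic carbon. Among the compounds with values here, the single measured step, an at least 5.7-fold higher number from compound 1 to compound 2 (0.76 log units; beyond the scatter), changed both the chain and the methoxy together, so it bears on this step only loosely. Restoring the methoxy is expected to lower the number, an expected at least 2.2-fold lower number from compound 2 to compound 3 (0.34 log units; beyond the scatter). Compound 3 is therefore estimated at 450 nM, with a range from 150 nM to 1500 nM.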

Compound 3, inhibition constant: 382 nM
Beside the measured number, compound 3's estimate is 1.2-fold (0.07 log units) above it; the measured number falls inside the stated range.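

With the chain held constant, methoxy in place of hydrogen on an aromatic carbon gives an at least 2.6-fold lower number from compound 2 to compound 3 (0.41 log units; beyond the scatter) in this assay. The earlier step changed the chain and the methoxy together, whereas this one isolates the methoxy and shows that it alone lowers the number on the longer chain. Compound 2 stands at a limit, so the full size of this step stays unknown: the limit of > 1000 nM in this assay, at which 1 of the 3 values shown sits.

As far as these compounds go, whether an ethoxy or a hydroxyl group at this place would lower the number as well remains open. So does the effect of methoxy on other carbons of the ring.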